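This account rests on a few compounds, and the source may have more. Where it says the series, first, only, none or still open, it means among the compounds named here.

Two compounds of the series carry numbers in a functional assay on cells (Lymphocyte, Homo sapiens); a higher number here means a weaker inhibitor, a lower number a stronger inhibitor. Compound 1 `CCCCCN1CCN(c2nc(N)nc3sc(-c4ccc(F)cc4)nc23)CC1` stands at the assay limit: in this assay compound 1 gives > 10000 nM, a limit rather than a measured value. For the measured compounds named here, compound 2 `Nc1nc(N2CCN(C(=O)COc3ccc(Cl)cc3)CC2)c2nc(CCc3ccc(F)cc3)sc2n1` is the only compound with a number; in this assay compound 2 gives 4400 nM, while the one other value shown is the limit of > 10000 nM in this assay, at which 1 of the 2 values shown sits. Compound 3 `Nc1nc(N2CCN(C(=O)COc3ccc(Cl)cc3)CC2)c2nc(CCCCc3ccc(F)cc3)sc2n1` remains unmeasured and carries 2-(4-fluorophenyl)ethyl in place of 4-fluorophenyl on a saturated chain carbon, two bonds along the chain from an aromatic carbon. Going by the values given here, no step between measured compounds exists to set the scale, so the expectation rests on the change alone: a small loss, near the edge of scatter, with the expected step being a 1.6-fold higher number from compound 2 to compound 3 (0.20 log units; within the scatter). Compound 3 is therefore estimated at 7000 nM in this assay, with a range from 2500 nM to 20000 nM.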

Compound 3, half-maximal inhibitory concentration: 920 nM
The estimate for compound 3 lay 7.6-fold (0.88 log units) above the measured number, and the stated range ends above it.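

In this assay, for the compounds shown here, 4-(4-fluorophenyl)butyl in place of 2-(4-fluorophenyl)ethyl gives a 4.8-fold lower number from compound 2 to compound 3 (0.68 log units; beyond the scatter) and is the first readable step. This position therefore responds to chain length, and on this single pair the added length brings a gain rather than a loss. Nothing shown gives a cause for that gain. Going by these compounds, whether a longer chain such as 5-(4-fluorophenyl)pentyl extends the gain or reverses it stays open. So does the outcome with an amine in place of the 4-fluorophenyl ring.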